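Pyrazoline series: sulfonyl for carbonyl on the ring nitrogen

This account rests on a few compounds, and the source may have more. Where it says the series, first, only, none or still open, it means among the compounds named here.

Three pyrazolines have been run in a functional assay on HepG2 cells (Homo sapiens) for cytotoxicity, read by MTT assay, with a stated time of 48 h; on this read-out higher numbers stand for weaker inhibition and lower numbers for stronger inhibition. Compound 1 `CC1=NN(S(=O)(=O)c2ccc(C)cc2)C(c2cc(Br)cc(Br)c2O)C1` gives "not active" (no number reported) in this assay. Compound 2 `CC1=NN(C(=O)CN2CCN(C)CC2)C(c2ccccc2O)C1` likewise gives "not active" (no number reported) in this assay. Among the measured compounds shown here, compound 3 `Cc1ccc(C(=O)N2N=C(c3cc4ccccc4oc3=O)CC2c2ccccc2)cc1` gives 52300 nM in this assay and so stands as the only entry with a number; the other two entries carry no number, so no step between measured compounds can be computed. Compound 4 `Cc1ccc(S(=O)(=O)N2N=C(c3cc4ccccc4oc3=O)CC2c2ccccc2)cc1` carries the change ((4-methylphenyl)sulfonyl in place of (4-methylphenyl)carbonyl on an amine nitrogen in a ring). For the measured compounds named here, with no measured step of this kind available, the expectation is a change of no more than the usual scatter, if anything toward weaker inhibition, the step from compound 3 to compound 4 being estimated at a 1.3-fold higher number from compound 3 to compound 4 (0.13 log units; within the scatter). Compound 4 is therefore expected to give 70000 nM in this assay, within a range of 25000 nM to 200000 nM.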

Compound 4, half-maximal inhibitory concentration: "not active" (no number reported)
For compound 4 the study gives words and no number; the estimate stays without a comparison.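

Compound 4 is reported in words with no number, so no new step can be read from compound 3 to compound 4. The compounds shown leave open how large the effect of (4-methylphenyl)sulfonyl in place of (4-methylphenyl)carbonyl is. No evidence on hand bears on this result.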